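Same Fluorine Swap Carried From Thioethers to Sulfones

The source may hold more compounds than are shown below. What is called first, only, known or untested is meant among the compounds shown, and "the series" means these compounds.

Measured so far:
compound 1, `CC(O)(CSc1ccc(S(F)(F)(F)(F)F)cc1)C(=O)Nc1ccc(S(F)(F)(F)(F)F)cc1`, 28000 nM
compound 2, `CC(O)(CSc1ccc(F)cc1)C(=O)Nc1ccc(S(F)(F)(F)(F)F)cc1`, 23000 nM
compound 3, `CC(O)(CS(=O)(=O)c1ccc(S(F)(F)(F)(F)F)cc1)C(=O)Nc1ccc(S(F)(F)(F)(F)F)cc1`, 15700 nM

All three compounds were tested in a functional assay on VCaP cells (Homo sapiens) for antiproliferative activity, read by propidium iodide staining, with a stated time of 96 h; on this read-out lower numbers stand for stronger inhibition and higher numbers for weaker inhibition. Compound 2 differs from compound 1 by one fluorine atom in place of a group of 6 heavy atoms (5 fluorine, 1 sulfur; no ring), on an aromatic carbon, and in this assay the step is a 1.2-fold lower number from compound 1 to compound 2 (0.09 log units; within the scatter). Compound 3 rests on a different core: how its core differs from that of compound 1 is not broken down here, and the values of compound 1 and compound 3 lie within the scatter of each other, as do those of compound 2 and compound 3, so no order among the three can be read.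

Compound 4, `CC(O)(CS(=O)(=O)c1ccc(F)cc1)C(=O)Nc1ccc(S(F)(F)(F)(F)F)cc1`, is not yet measured. It differs from compound 3 by one fluorine atom in place of a group of 6 heavy atoms (5 fluorine, 1 sulfur; no ring), on an aromatic carbon. The place is described in the same words as for the pair of compound 1 and compound 2, so this is the same change, made once on each core. Because a 1.2-fold lower number from compound 1 to compound 2 (0.09 log units; within the scatter) is a small step, compound 4 is expected to stay close to compound 3, with an expected step of a 1.2-fold lower number from compound 3 to compound 4 (0.08 log units; within the scatter). Compound 4 is estimated at 13000 nM, between 6000 nM and 30000 nM.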

Compound 4, half-maximal inhibitory concentration: 34200 nM
For compound 4 the middle estimate is 2.6-fold (0.42 log units) below the measured one, and the stated range ends below it.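

In this assay, putting one fluorine atom in place of the group of 5 fluorine atoms and 1 sulfur atom on the second core gives a 2.2-fold higher number from compound 3 to compound 4 (0.34 log units; beyond the scatter), and set beside the earlier step on the first core, the two cannot be told apart: the same change on two cores in this assay, a 1.2-fold lower number (0.09 log units; within the scatter) from compound 1 to compound 2 and a 2.2-fold higher number (0.34 log units; beyond the scatter) from compound 3 to compound 4, 2.7-fold (0.42 log units) apart, within the scatter of two such steps The steps point in opposite directions, but the gap between them does not show that the outcome of this change depends on the core. Nor does it show that the change carries over unaltered, since each core supplies only one pair and a shared effect rests on no more than those two steps.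

The compounds shown leave open how other groups on that aromatic carbon, such as a trifluoromethyl, a nitrile or an amine, would fare on either core. They also leave open whether the same change would give a similar step on a core carrying a sulfoxide in place of the thioether or sulfone.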